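Extending the Methyl Group on the Shared Core

The source may hold more compounds than are shown below. What is called first, only, known or untested is meant among the compounds shown, and "the series" means these compounds.

Three compounds were measured in an assay on HEK293 cells for binding affinity to 5-hydroxytryptamine receptor 7 (Homo sapiens), read by radioligand binding, tested at 1 uM; on this read-out lower numbers stand for less inhibition and higher numbers for more inhibition at the one concentration tested (going by the name of the read-out):

compound 1 `CN1CCCN(CCn2ccc3ccc(N)cc32)CC1`: 0%
compound 2 `CN1CCCN(CCn2ccc3ccc(OCc4ccccc4)cc32)CC1`: 28%
compound 3 `Cc1ccc2ccn(CCN3CCCN(C)CC3)c2c1`: 62%

Compound 3 stands highest of the three. The step of a number 62 percentage points higher from compound 1 to compound 3 (beyond the scatter) and the step of a number 34 percentage points higher from compound 2 to compound 3 (beyond the scatter) both lie beyond the scatter, as does the step of a number 28 percentage points higher from compound 1 to compound 2 (beyond the scatter). Among the groups placed on that aromatic carbon, methyl gives the largest inhibition, benzyloxy a smaller one and amino none.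

Compound 4 `CCc1ccc2ccn(CCN3CCCN(C)CC3)c2c1` is the next compound, not yet measured in this assay. It differs from compound 3 by methyl in place of hydrogen on a saturated chain carbon bound to an aromatic carbon. Among the compounds with values here, none of the measured steps concerns this change: each of them exchanges one group for another on the aromatic carbon itself, whereas here the methyl group of compound 3 is lengthened by one carbon. The nearest comparison is that the larger benzyloxy group gave a smaller inhibition than methyl, which suggests that growing the group is not rewarded, but that comparison is indirect.

Compound 4 is therefore expected to stay close to compound 3, with a step of a number 7 percentage points lower from compound 3 to compound 4 (within the scatter) that may fall within the scatter or slightly below it. The estimate for compound 4 is 55%, with a range from 30% to 78%.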

Compound 4, a percentage reported as inhibition, at one concentration (the size of the read-out at that concentration, not a potency): 66%
Estimate against measurement, compound 4: 11 percentage points below; measured number inside the range.
By their numbers in this assay, from the lowest: compound 1; then compound 2; then compounds 3 and 4 (each within the scatter of the next).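

In this assay, within the data shown here, the step of a number 4 percentage points higher from compound 3 to compound 4 (within the scatter) is the first reading of a change made on the group itself rather than an exchange of one group for another on the aromatic carbon. It shows that methyl in place of hydrogen on a saturated chain carbon bound to an aromatic carbon keeps the two compounds within the scatter of each other, so the numbers for methyl and ethyl are level in this read-out. Ethyl also stands clear of the other two groups on that aromatic carbon, with the step of a number 38 percentage points higher from compound 2 to compound 4 (beyond the scatter) from benzyloxy and the step of a number 66 percentage points higher from compound 1 to compound 4 (beyond the scatter) from amino, which puts methyl and ethyl together at the top of the series; nothing measured here bears on what lies behind these numbers.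

The compounds shown leave open whether a propyl group or a longer chain on that aromatic carbon would stay with methyl and ethyl or fall toward benzyloxy. They also leave open how a methoxy group, or a hydroxyl or an amine at the end of the ethyl chain, would read on the same core.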